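A few compounds are considered here, and "the series" means these few. Any claim that something is new, unique, unknown or untested is made for them only; others in the source may bear on it.

Compound 3 `Fc1ccccc1Cc1nc(-c2ncn[nH]2)n2ccccc12` sits in the middle of the three measured compounds in an ADME assay on MDCKII-LE cells (Canis lupus familiaris) for permeability, in the apical to basolateral direction; a higher number here means that the compound crosses the layer faster, a lower number that the compound crosses the layer more slowly. Compound 3 gives 8 10^-6 cm/s, compound 1 `Fc1ccccc1Cc1nc(-c2nc(C(F)(F)F)n[nH]2)c2ccccn12` gives 17 10^-6 cm/s, and compound 2 `Cc1n[nH]c(-c2nc(Cc3ccccc3F)c3ccccn23)n1` gives 1 10^-6 cm/s. The step from compound 2 to compound 3, hydrogen in place of methyl on an aromatic carbon, brings an 8.0-fold higher number from compound 2 to compound 3 (0.90 log units; beyond the scatter).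

Compound 4 `Fc1ccccc1Cc1nc(-c2nc(C(F)(F)C(F)(F)F)n[nH]2)n2ccccc12` is the next step from compound 3: 1,1,2,2,2-pentafluoroethyl in place of hydrogen on an aromatic carbon. The change sits on an aromatic carbon of a five-membered aromatic ring with 3 nitrogen, between two ring nitrogen atoms. Two measured facts bear on it. The step from compound 2 to compound 3 shows that a methyl on that carbon goes with a clearly lower number than a hydrogen. Among the compounds with values here, on the other hand compound 1, which carries a trifluoromethyl on the same kind of carbon but on a differently arranged core, gives 17 10^-6 cm/s, above compound 3 at 8 10^-6 cm/s, though no direct step between them is available. A fluorinated chain thus does not appear to lower the number the way a methyl does, and compound 4 is therefore expected to show a step of a 1.5-fold higher number from compound 3 to compound 4 (0.18 log units; within the scatter), within or only slightly beyond the scatter. Compound 4 is estimated at 12 10^-6 cm/s, with a range from 5 10^-6 cm/s to 30 10^-6 cm/s.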

Compound 4, apparent permeability: 3 10^-6 cm/s
The estimate for compound 4 lay 4.0-fold (0.60 log units) above the measured number, outside the stated range (below it).
By their numbers in this assay, from the lowest: compound 2; then compound 4; then compound 3; then compound 1.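

On the shared core, a fluorinated chain on this carbon also goes with a lower number than hydrogen: in this assay 1,1,2,2,2-pentafluoroethyl in place of hydrogen brings a 2.7-fold lower number from compound 3 to compound 4 (0.43 log units; beyond the scatter) and leaves hydrogen highest of the three groups seen at this position. The two substituted compounds are not alike either, since 1,1,2,2,2-pentafluoroethyl in place of methyl brings a 3.0-fold higher number from compound 2 to compound 4 (0.48 log units; beyond the scatter) and the position therefore separates these two groups as well as setting both apart from hydrogen. Nothing in the data shown gives a reason for this order.

Going by these compounds, compound 1 carries trifluoromethyl on a differently arranged core and differs from these compounds in more than one place, so its number cannot be set against this series, and how trifluoromethyl behaves on the shared core stays open. Also open, on these data alone, is whether a group of another kind on this carbon, such as an amine or a carboxylic acid, would stand level with hydrogen or fall with methyl and 1,1,2,2,2-pentafluoroethyl.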